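Replacing ethyl on the ring nitrogen with a cyclopropylphenyl group

The source may report more compounds than this note shows. Statements on the series, on what has been measured and on what is new or still open speak of the compounds shown alone.

Of the compounds shown here, three of one series have been measured in a functional assay on HOS-TE85 cells (Homo sapiens) for inhibition, read by CCK-8 assay, with a stated time of 72 h; a higher number here means a weaker inhibitor, a lower number a stronger inhibitor. Compound 1 `COc1ccccc1N1C(=O)CSC1c1cc(F)cc(C(=O)NCCCCc2ccccc2)c1` gives 40.9 nM in this assay. Compound 3 `CCOC(=O)c1sc(N2C(=O)CSC2c2cccc(C(=O)NCCCCn3cccn3)c2)nc1C` gives 430 nM. Compound 2 `CCN1C(=O)CSC1c1cccc(C(=O)NCCCCc2ccccc2)c1` is reported in this assay only as a limit, > 1000 nM, so its inhibition could not be quantified; it sits at the limit of > 1000 nM in this assay, at which 1 of the 3 values shown sits. Compound 1 and compound 3 show measurable values, whereas compound 2 does not.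

Compound 4 `O=C(NCCCCc1ccccc1)c1cccc(C2SCC(=O)N2c2ccc(C3CC3)cc2)c1` has not yet been measured in this assay. It differs from compound 2 in one place: 4-cyclopropylphenyl in place of ethyl on an amide-type nitrogen in a ring. Among the measured compounds shown here, no step between two measured compounds isolates this particular change, so any expectation rests on where compound 2 stands and on the values of compound 1 and compound 3, which both carry an aromatic ring on that nitrogen. The step from compound 2 to compound 4 is expected to be a clear gain in potency, well beyond the scatter, an at least 10-fold lower number from compound 2 to compound 4 (1.00 log units; beyond the scatter). Compound 4 is accordingly estimated to give 100 nM, with a range from 30 nM to 400 nM.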

Compound 4, half-maximal inhibitory concentration: 217 nM
Compound 4: middle estimate off by 2.2-fold (0.34 log units), on the low side, and the stated range covers the measured number.
By their numbers in this assay, from the lowest: compound 1; then compounds 4 and 3 (each within the scatter of the next). At a limit, above all of these: compound 2.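

In this assay, among the compounds shown here, 4-cyclopropylphenyl in place of ethyl on the amide-type nitrogen in the ring gives an at least 4.6-fold lower number from compound 2 to compound 4 (0.66 log units; beyond the scatter), the first step in which this position alone changes. With the rest of compound 2 kept, an aromatic group on this nitrogen therefore brings the value into the measurable range, something compound 1 and compound 3 could only suggest, as they also differ from compound 2 in other places. The true size of the step remains unknown, since compound 2 is reported only as a limit: the limit of > 1000 nM in this assay, at which 1 of the 4 values shown sits.

As far as these compounds go, how much of the gain belongs to the cyclopropyl ring and how much to the phenyl ring stays open. Also open, from the compounds shown here alone, is whether plain phenyl, cyclohexyl or an aminophenyl group on this nitrogen would give a similar step.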